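The source may hold more compounds than are shown below. What is called first, only, known or untested is meant among the compounds shown, and "the series" means these compounds.

Measured so far in an ADME assay on microsomes from liver (Homo sapiens) for metabolic stability; a higher number here means that the compound lasts longer, a lower number that the compound disappears faster:
- compound 1 `COC[C@H](NC(=O)[C@H](CSC)NC(=O)c1cc(C)on1)C(=O)N[C@@H](CC(C)C)C(=O)[C@@]1(C)CO1`: 0.382 h
- compound 2 `CSC[C@H](NC(=O)c1cc(C)on1)C(=O)N[C@@H](CSC)C(=O)N[C@@H](CC(C)C)C(=O)[C@@]1(C)CO1`: 0.108 h
- compound 3 `COC[C@H](NC(=O)c1cc(C)on1)C(=O)NCC(=O)N[C@@H](CC(C)C)C(=O)[C@@]1(C)CO1`: 1.86 h

Compound 3, at 1.86 h, has the highest number of the three, and its gaps to compound 1 and compound 2 both lie beyond the scatter.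

The next compound to consider is compound 4 `CSC[C@H](NC(=O)c1cc(C)on1)C(=O)NCC(=O)N[C@@H](CC(C)C)C(=O)[C@@]1(C)CO1`, which differs from compound 3 as follows: methylsulfanyl in place of methoxy on a saturated chain carbon, two bonds along the chain from an amide-type nitrogen and a carbonyl carbon. In words, this is methylsulfanyl in place of methoxy on a saturated chain carbon, two bonds along the chain from an amide-type nitrogen and a carbonyl carbon.

Among the measured compounds shown here, only one measured step bears on this change. The same replacement gives a 3.5-fold lower number from compound 1 to compound 2 (0.55 log units; beyond the scatter), a modest step beyond the scatter. It is a single precedent, and the surroundings differ: compound 1 already carries a methylsulfanyl group, whereas compound 3 carries none. For the measured compounds named here, the size of that step may therefore not transfer exactly, and the data hold no second pair to check it against.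

A drop of similar size in this assay is expected, and the estimate amounts to a 3.5-fold lower number from compound 3 to compound 4 (0.55 log units; beyond the scatter). Compound 4 is estimated at 0.53 h, with an expected range of 0.22 h to 1.2 h.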

Compound 4, half-life: 0.527 h
Compound 4: middle estimate off by 1.0-fold (0.00 log units), on the high side; measured number inside the range.
By their numbers in this assay, from the lowest: compound 2; then compounds 1 and 4 (each within the scatter of the next); then compound 3.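

In this assay, the replacement of methoxy by methylsulfanyl on this saturated chain carbon now has a second pair, and the new pair gives a 3.5-fold lower number from compound 3 to compound 4 (0.55 log units; beyond the scatter), on a core with no other methylsulfanyl group. The size of the step therefore carries over between a core with a second methylsulfanyl group and one without it: the same change on two cores in this assay, a 3.5-fold lower number (0.55 log units; beyond the scatter) from compound 1 to compound 2 and a 3.5-fold lower number (0.55 log units; beyond the scatter) from compound 3 to compound 4, 1.0-fold (0.00 log units) apart, within the scatter of two such steps

Among the compounds shown here, the new compound also gives a first reading on the other saturated chain carbon bound to an amide-type nitrogen and a carbonyl carbon: hydrogen in place of (methylsulfanyl)methyl gives a 4.9-fold higher number from compound 2 to compound 4 (0.69 log units; beyond the scatter), beyond the scatter, whereas hydrogen in place of methoxymethyl gives a 1.4-fold higher number from compound 1 to compound 4 (0.14 log units; within the scatter), within it, so in these two pairs the outcome at that carbon differs with the group that leaves.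

As far as these compounds go, whether a hydroxy group, an amine or a longer chain such as ethylsulfanyl on the first carbon would sit with compound 3 or with compound 4 remains open. The two pairs fix the size of the replacement step on these two cores only and say nothing about its origin.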